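The source may hold more compounds than are shown below. What is called first, only, known or untested is meant among the compounds shown, and "the series" means these compounds.

Measured so far: compound 1 `CCCN(CCC)CCNc1n[n+]([O-])c2ccc(C(C)C)cc2[n+]1[O-]` gives 900 nM in a functional assay on SiHa cells (Homo sapiens) for cytotoxicity, with a stated time of 4 h; a higher number here means a weaker inhibitor, a lower number a stronger inhibitor; compound 2 `CCCN(CCC)CCNc1n[n+]([O-])c2ccc(C(C)(C)C)cc2[n+]1[O-]` gives 3800 nM; compound 3 `CCOc1ccc2c(c1)[n+]([O-])c(NCCN(C)C)n[n+]2[O-]` gives 800 nM.

From compound 1 to compound 2 the change is methyl in place of hydrogen on a saturated chain carbon bound to an aromatic carbon and two saturated chain carbons, and it brought a 4.2-fold higher number from compound 1 to compound 2 (0.63 log units; beyond the scatter). Compound 4 `CC(C)Oc1ccc2c(c1)[n+]([O-])c(NCCN(C)C)n[n+]2[O-]` is not yet measured; it differs from compound 3 by methyl in place of hydrogen on a saturated chain carbon bound to an oxygen on an aromatic ring and a saturated chain carbon. This is the same kind of change, though the place differs: in compound 2 the carbon is bound to an aromatic carbon and two saturated chain carbons, in compound 4 to an oxygen on an aromatic ring and a saturated chain carbon. The difference between the two cores of compound 1 and compound 3 is not broken down here. Because the same kind of change gave a 4.2-fold higher number from compound 1 to compound 2 (0.63 log units; beyond the scatter), compound 4 is expected to show a smaller weakening, a 2.0-fold higher number from compound 3 to compound 4 (0.30 log units; within the scatter). For compound 4 the estimate in this assay is 1600 nM, between 700 nM and 4500 nM.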

Compound 4, half-maximal inhibitory concentration: 1600 nM
Estimate against measurement, compound 4: no gap at the digits printed; the measured number falls inside the stated range.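

In this assay, methyl in place of hydrogen on a saturated chain carbon bound to an oxygen on an aromatic ring and a saturated chain carbon gave a 2.0-fold higher number from compound 3 to compound 4 (0.30 log units; within the scatter). Set beside the earlier step, the two results cannot be told apart: the same change on two cores in this assay, a 4.2-fold higher number (0.63 log units; beyond the scatter) from compound 1 to compound 2 and a 2.0-fold higher number (0.30 log units; within the scatter) from compound 3 to compound 4, 2.1-fold (0.32 log units) apart, within the scatter of two such steps. This fits the change carrying over from one core to the other, but it rests on a single pair for each core, with the change at a different place in each, so it does not show that the step is the same size on every core in this series.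

Going by these compounds, it remains open how a longer chain such as butoxy would read in place of isopropoxy. Also open, on these data alone, is how an amine or a carboxylic acid on the core would read.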